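The source may hold more compounds than are shown below. What is called first, only, known or untested is meant among the compounds shown, and "the series" means these compounds.

Three compounds share one core and differ only in the aryl group carried on an aromatic nitrogen. Compound 1, `Oc1cc(C(F)(F)F)ccc1-c1nc(-c2ccccc2O)n(-c2ccc(Br)cc2)n1`, gives 69.4% in a functional assay on PC-12 cells (Rattus norvegicus) for cytotoxicity, read by MTT assay, with stated times of 2 h and 24 h, tested at 1 uM; a lower number here means a weaker effect, a higher number a stronger effect of the compound at the concentration tested. Compound 2, `Oc1cc(C(F)(F)F)ccc1-c1nc(-c2ccccc2O)n(-c2ccccc2Cl)n1`, gives 70.1% in the same assay, and compound 3, `Oc1cc(C(F)(F)F)ccc1-c1nc(-c2ccccc2O)n(-c2cccc(C(F)(F)F)c2)n1`, gives 71.5%. Compound 2 stands among three values that all lie within the usual scatter of one another: nearest to it is compound 1, with a number 0.7 percentage points higher from compound 1 to compound 2 (within the scatter), and furthest is compound 3, with a number 1.4 percentage points higher from compound 2 to compound 3 (within the scatter).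

The unmeasured compound 4, `Oc1cc(C(F)(F)F)ccc1-c1nc(-c2ccccc2O)n(-c2cc(F)cc(F)c2)n1`, differs from compound 2 by 3,5-difluorophenyl in place of 2-chlorophenyl on an aromatic nitrogen. Every measured step changes the aryl group on that same aromatic nitrogen, and none of them moved the read-out beyond the scatter: a number 0.7 percentage points higher from compound 1 to compound 2 (within the scatter), a number 1.4 percentage points higher from compound 2 to compound 3 (within the scatter) and a number 2.1 percentage points higher from compound 1 to compound 3 (within the scatter). Nothing in these data therefore points to a step in either direction for a further aryl exchange at this place, and no step beyond the scatter is expected in this assay.

Compound 4 is accordingly expected to give about 70.5%, with a range from 63% to 78%. This estimate means an expected step of a number 0.4 percentage points higher from compound 2 to compound 4 (within the scatter), which is expected to stay within the scatter.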

Compound 4, a percentage reported as activity, at one concentration (the size of the read-out at that concentration, not a potency): 75.5%
For compound 4 the middle estimate is 5 percentage points below the measured one; the measured number falls inside the stated range.
By their numbers in this assay, from the lowest: compounds 1, 2, 3 and 4 (each within the scatter of the next).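

Going by these compounds alone, compound 4 brings a fourth aryl group to this aromatic nitrogen, and in this assay the exchange gives a number 5.4 percentage points higher from compound 2 to compound 4 (within the scatter) and a number 4 percentage points higher from compound 3 to compound 4 (within the scatter) and a number 6.1 percentage points higher from compound 1 to compound 4 (within the scatter) so that no step at this place has yet left the scatter. The earlier compounds shown here each carried a single substituent on this aryl ring, one bromine, one chlorine or one trifluoromethyl group, and the result extends the same picture to a ring with two fluorine atoms, since the read-out does not separate 3,5-difluorophenyl from any of those three groups. No measurement accompanies these numbers that would account for them or tie them to any property of the groups.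

The compounds shown leave open whether an amine or a carboxylic acid on this aryl ring, or a longer alkyl chain in place of the ring, would give a step beyond the scatter. All four keep the rest of the shared core unchanged, including the 2-hydroxyphenyl group, so they say nothing about exchanges at any other place.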